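From bromo to methoxy on compound 1

This account rests on a few compounds, and the source may have more. Where it says the series, first, only, none or still open, it means among the compounds named here.

Within the data shown here, in a functional assay on MCF7 cells (Homo sapiens) for cytotoxicity, read by MTT assay, with a stated time of 96 h (a higher number here means a weaker inhibitor, a lower number a stronger inhibitor), compound 1 `Cc1cc2c(c(=O)o1)C(c1ccc(Br)cc1)C(C#N)=C(N)O2` gives 35000 nM as the highest of three numbers so far. Compound 2 `Cc1cc2c(c(=O)o1)C(c1cccs1)C(C#N)=C(N)O2` gives 15000 nM and compound 3 `Cc1cc2c(c(=O)o1)C(c1ccc(Cl)s1)C(C#N)=C(N)O2` gives 12000 nM as well. Compound 4 `COc1ccc(C2C(C#N)=C(N)Oc3cc(C)oc(=O)c32)cc1` has methoxy in place of bromo on an aromatic carbon and awaits measurement. Among the measured compounds shown here, no measured step makes this exact swap. The nearest small change, chloro in place of hydrogen, gave a 1.3-fold lower number from compound 2 to compound 3 (0.10 log units; within the scatter) as its result. Replacing the whole 4-bromophenyl gave a 2.3-fold lower number from compound 1 to compound 2 (0.37 log units; beyond the scatter) and a 2.9-fold lower number from compound 1 to compound 3 (0.46 log units; beyond the scatter) as modest steps. A small downward move is therefore expected in this assay for this single swap. The estimated step is a 1.5-fold lower number from compound 1 to compound 4 (0.16 log units; within the scatter) and may well stay within the scatter. Compound 4 is estimated at 24000 nM with 10000 nM to 50000 nM as its expected range.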

Compound 4, half-maximal inhibitory concentration: 57000 nM
Estimate against measurement, compound 4: 2.4-fold (0.38 log units) below, and the stated range ends below it.
By their numbers in this assay, from the lowest: compounds 3 and 2 (each within the scatter of the next); then compounds 1 and 4 (each within the scatter of the next).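

In this assay, methoxy on this aromatic carbon, para to a large group, gives a 1.6-fold higher number from compound 1 to compound 4 (0.21 log units; within the scatter), so this swap does not separate the two compounds, even though methoxy carries a hydrogen-bond acceptor and bromo does not. The steps beyond the scatter so far came from replacing the whole 4-bromophenyl, not from changing the group on it. Nothing available explains this result.

Going by these compounds, whether an amine or a carboxylic acid here would move the number beyond the scatter remains open. So does the effect of a longer chain in place of methoxy.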